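This account rests on a few compounds, and the source may have more. Where it says the series, first, only, none or still open, it means among the compounds named here.

Measured so far:
Compound 1 `COc1ccc(-c2c(C)nc3c(N4CC[C@@H](NC(C)=O)C4)cc(Cl)nn23)cc1OC` gives > 95% in an ADME assay on microsomes from liver (Homo sapiens) for metabolic stability, read by LC-MS, with NADPH named in the record, with a stated time of 60 min, tested at 1 uM, in the absence of a further agent (a higher number here means that more of the compound is left, a lower number that less of the compound is left), which is a limit of the assay.
Compound 2 `COc1ccc(-c2c(C)nc3c(N4CC[C@@H](NS(=O)(=O)c5ccccc5)C4)cc(C)nn23)cc1OC` gives > 95% in this assay, also a limit.
Compound 3 `COc1ccc(-c2c(C)nc3c(N4CC[C@@H](NS(=O)(=O)c5ccc(Cl)cc5)C4)cc(C)nn23)cc1OC` gives > 95% in this assay, again a limit.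

All three values therefore rest at the limit of > 95% in this assay, at which 3 of the 3 values shown sit. Compound 4 `COc1ccc(-c2c(C)nc3c(N4CC[C@@H](NC(C)=O)C4)ccnn23)cc1OC` has not yet been measured. It differs from compound 1 by hydrogen in place of chloro on an aromatic carbon. The same kind of change is made from compound 3 to compound 2, (hydrogen in place of chloro on an aromatic carbon), but there the place is on a six-membered aromatic ring of carbon only, para to a large group, whereas in compound 1 it is on a six-membered aromatic ring with two nitrogen, part of a fused system; that measured step is a step that the two limits leave unreadable from compound 3 to compound 2. The difference between the cores of compound 1 and compound 3 is not broken down here. Because compound 1 already stands at > 95%, the step of a number no higher from compound 1 to compound 4 (the limit leaves the size open) is expected to stay hidden by the limit. Compound 4 is estimated at 95% in this assay.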

Compound 4, percent of the compound remaining: > 95%
Compound 4: only a limit was reported (the forecaster's own chance of this, stated with the estimate: 80%); the middle value lies on the limit itself.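

No step can be read between compound 1 and compound 4, as both values in this assay are limits: the limit of > 95% in this assay, at which 4 of the 4 values shown sit.

The compounds shown leave open how far any of them truly differs in this assay, including what hydrogen in place of chloro does.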